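Arylpiperazine variation on a spirocyclic oxindole series

A few compounds are considered here, and "the series" means these few. Any claim that something is new, unique, unknown or untested is made for them only; others in the source may bear on it.

Compounds measured so far:
Compound 1, `CCC1(CCCCN2CCN(c3ccc(Cl)cc3)CC2)C(=O)Nc2cc(F)ccc21`, 215 nM.
Compound 2, `CCC1(CCCCN2CCN(c3ccccc3Cl)CC2)C(=O)Nc2ccccc21`, 64 nM.
Compound 3, `CCC1(CCCCN2CCN(c3ccc(Cl)cc3)CC2)C(=O)Nc2cc(F)c(Cl)cc21`, 191 nM.

All three were tested in an assay on membranes from frontal cortex for displacement of a labelled ligand from Adrenergic receptor alpha-1 (Rattus norvegicus), read by scintillation counting, with a stated time of 45 min; on this read-out higher numbers stand for weaker inhibition and lower numbers for stronger inhibition. Compound 2 stands at the lowest number of the three: compound 3 sits at a higher number by a margin beyond the scatter, and compound 1 sits higher still, also beyond the scatter. For the measured compounds named here, the only single-place step among the measured compounds, a 1.1-fold lower number from compound 1 to compound 3 (0.05 log units; within the scatter), concerns chloro added on an aromatic carbon of the core and lies within the scatter.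

Compound 4, `CCC1(CCCCN2CCN(c3ccc(Cl)c(Cl)c3)CC2)C(=O)Nc2ccccc21`, has not yet been measured in this assay. It differs from compound 2 by 3,4-dichlorophenyl in place of 2-chlorophenyl on an amine nitrogen in a ring. Going by the values given here, no measured step bears directly on this change, since compound 1 and compound 3 carry both a different chlorophenyl and a substituted core, so their higher numbers relative to compound 2 cannot be assigned to the aryl group alone. Among the compounds with values here, with no direct precedent, a modest move toward a higher number is expected, a 1.9-fold higher number from compound 2 to compound 4 (0.27 log units; within the scatter), with wide uncertainty. Compound 4 is therefore estimated at 120 nM, in the range 40 nM to 400 nM.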

Compound 4, inhibition constant: 125 nM
Compound 4: the middle estimate sits 1.0-fold (0.02 log units) below what was measured; the range from low to high includes it.
By their numbers in this assay, from the lowest: compounds 2, 4, 3 and 1 (each within the scatter of the next, the first and the last beyond it).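

Among the compounds shown, this is the first step at the amine nitrogen in a ring with the shared core held constant, and it replaces 2-chlorophenyl with 3,4-dichlorophenyl. In this assay, the change gives a 2.0-fold higher number from compound 2 to compound 4 (0.29 log units; within the scatter), which lies within the scatter, so these two aryl groups are not separated at this position, even though the entering group carries one more chlorine. For the compounds shown here, no measurement available here accounts for this result, and the swap alters both the number of chlorines and where they sit on the phenyl ring, so the single step cannot divide its outcome between the two.

The compounds shown leave open how far this tolerance extends on the same core, for instance to an unsubstituted phenyl or to a phenyl carrying a methoxy group or a nitrile in place of chlorine. They also leave open whether the higher numbers of the fluorinated compounds belong to their core or to their aryl group, and the other pairs offer no single-place step that could answer this.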